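This account rests on a few compounds, and the source may have more. Where it says the series, first, only, none or still open, it means among the compounds named here.

Measured compounds:
- compound 1 `COc1ccc2[nH]c(C(=O)N3CC(=O)N(Cc4ccccc4)[C@@H](COc4ccccc4)C3)cc2c1`: 12200 nM
- compound 2 `COc1ccc2[nH]c(C(=O)N3CC(=O)N(Cc4ccc[nH]4)[C@@H](Cc4ccccc4)C3)cc2c1`: 38400 nM

In a physicochemical assay for solubility, read by spectrophotometry, in phosphate buffer, with a stated time of 2 h, at pH 7.4 (on this read-out lower numbers stand for lower solubility and higher numbers for higher solubility), compound 1 gives the lowest of the two numbers; compound 2 shows a higher number, and the gap between them lies beyond the scatter. Compound 3 `COc1ccc2[nH]c(C(=O)N3CC(=O)N(Cc4ccccc4)[C@@H](CN4CCc5ccccc5C4)C3)cc2c1` differs from compound 1 in one place: 1,2,3,4-tetrahydroisoquinolin-2-yl in place of phenoxy on a saturated chain carbon bound to a saturated ring carbon. Among the compounds with values here, no step between measured compounds bears on this change, so the expectation rests on the values alone. A moderate rise in solubility is expected, the step from compound 1 to compound 3 being estimated as a 3.3-fold higher number from compound 1 to compound 3 (0.52 log units; beyond the scatter). Compound 3 is expected to give about 40000 nM, within 10000 nM to 160000 nM.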

Compound 3, solubility: 9000 nM
Compound 3: middle estimate off by 4.4-fold (0.65 log units), on the high side; the whole stated range lies above it.
By their numbers in this assay, from the lowest: compounds 3 and 1 (each within the scatter of the next); then compound 2.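

In this assay, placing 1,2,3,4-tetrahydroisoquinolin-2-yl in place of phenoxy on a saturated chain carbon bound to a saturated ring carbon gives a 1.4-fold lower number from compound 1 to compound 3 (0.13 log units; within the scatter). Within the data shown here, this is the first single-place comparison at this position, and on this read-out it does not separate the two groups, although the entering group brings a non-aromatic ring and a nitrogen. No available evidence accounts for this result. As far as these compounds go, whether a carboxylic acid or a primary amine at this place would give a step beyond the scatter remains open.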